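Oxazolidinone series: cytotoxicity notes on a side-chain swap

The compounds below may be only part of what the source reports. "The series", "measured", "known", "first", "only" and "open" are said of these compounds alone.

Measured so far:
- compound 1 `CCN1CCN(C[C@H]2CN(c3ccc(-n4cc(-c5ccccn5)cn4)c(F)c3)C(=O)O2)CC1`: 99 ug/mL
- compound 2 `COC(=O)CC1CCN(C[C@H]2CN(c3ccc(-n4cc(-c5ccccn5)cn4)c(F)c3)C(=O)O2)CC1`: 224 ug/mL

In an ADME assay on HEK293-A cells (Homo sapiens) for cytotoxicity, read by MTT assay, with a stated time of 48 h (on this read-out higher numbers stand for weaker inhibition and lower numbers for stronger inhibition), compound 1 gives 99 ug/mL, the lowest of the two numbers shown; its nearest neighbour is compound 2, which in this assay gives 224 ug/mL. Among the compounds with values here, the single measured step, a 2.3-fold higher number from compound 1 to compound 2 (0.35 log units; beyond the scatter), is modest.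

Compound 3 `O=C1O[C@@H](Cn2ccnc2)CN1c1ccc(-n2cc(-c3ccccn3)cn2)c(F)c1` is to be measured in this assay. It differs from compound 1 as follows: 1H-imidazol-1-yl in place of 4-ethylpiperazin-1-yl on a saturated chain carbon bound to a saturated ring carbon.

Within the data shown here, only the step from compound 1 to compound 2 is available for comparison, and it exchanges the 4-ethylpiperazin-1-yl group for a different group than the one entering here, so it bears on this change only loosely. Among the measured compounds shown here, no measured step covers 1H-imidazol-1-yl at this place. The expectation is therefore a number close to that of compound 1, with any step likely small: a 1.2-fold higher number from compound 1 to compound 3 (0.08 log units; within the scatter) is the expected move in this assay. Compound 3 is estimated at 120 ug/mL, within a range of 50 ug/mL to 300 ug/mL.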

Compound 3, half-maximal inhibitory concentration: > 400 ug/mL
Compound 3 ended at the assay's limit (the forecaster's own chance of this, stated with the estimate: 15%); middle value at least 3.3-fold (0.52 log units) from the limit.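

In this assay compound 3 gives > 400 ug/mL, which is a limit of the assay and not a number: the limit of > 400 ug/mL in this assay, at which 1 of the 3 values shown sits.

Putting 1H-imidazol-1-yl in place of 4-ethylpiperazin-1-yl on a saturated chain carbon bound to a saturated ring carbon gives an at least 4.0-fold higher number from compound 1 to compound 3 (0.60 log units; beyond the scatter), so a five-membered aromatic ring at this place also moves the number up from that of the ethylpiperazine, as the piperidine ester did. The other step, an at least 1.7-fold higher number from compound 2 to compound 3 (0.25 log units; that floor lies within the scatter), has a floor within the scatter and sets no order between those two compounds.

Going by these compounds, the true size of both steps stays unknown, and this single change alters ring size and aromatic character together, leaving the two unseparated. On these data alone, how a morpholine, a triazole or a free carboxylic acid would read at this place remains open.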